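Shortening a Butyl Chain on a Cytotoxicity Test

The compounds below may be only part of what the source reports. "The series", "measured", "known", "first", "only" and "open" are said of these compounds alone.

- compound 1 `CCCCC1(CCCC)C[C@@H](CNCCCn2ccnc2)[C@@](CCCC)(OC)OO1`: 32500 nM
- compound 2 `CO[C@@]1(C)OOC(c2ccc(F)cc2)(c2ccc(F)cc2)C[C@H]1CNCCCn1ccnc1`: 93600 nM
- compound 3 `COC(=O)C1CC(c2ccccc2)(c2ccccc2)OOC1(C)OC`: "not determined" (no result reported)

These results come from an ADME assay on Vero cells (Chlorocebus sabaeus) for cytotoxicity, read by resazurin assay, with a stated time of 72 h; on this read-out higher numbers stand for lower toxicity in this test and lower numbers for higher toxicity in this test. Among the compounds with values here, only two of the three compounds have a number, and compound 1 holds the lower one, so it is the more toxic of the pair in this test. The gap up to compound 2 lies beyond the usual scatter of repeated measurements.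

The next compound to be measured is compound 4 `CCCCC1(CCCC)C[C@@H](CNCCCn2ccnc2)[C@@](C)(OC)OO1`. It differs from compound 1 in one place: hydrogen in place of propyl on a saturated chain carbon bound to a saturated ring carbon. Put simply, hydrogen stands in place of propyl on a saturated chain carbon bound to a saturated ring carbon, which also reads as butyl to methyl.

Within the data shown here, no two measured compounds differ in just one place, so the data give no direct size for this change. Compound 2 also carries methyl in that place and gives 93600 nM, but it differs from compound 1 elsewhere too, which makes it only a weak hint. A modest move in this assay towards a higher number therefore seems likely, and it may not clear the scatter. The expected step is a 1.8-fold higher number from compound 1 to compound 4 (0.27 log units; within the scatter). For compound 4 the estimate is 60000 nM, with an expected range from 28000 nM to 130000 nM.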

Compound 4, half-maximal cytotoxic concentration: 74500 nM
Beside the measured number, compound 4's estimate is 1.2-fold (0.09 log units) below it; the range from low to high includes it.
By their numbers in this assay, from the lowest: compound 1; then compounds 4 and 2 (each within the scatter of the next).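

Within the data shown here, this pair gives the first direct reading of a single change: going from butyl to methyl brings a 2.3-fold higher number from compound 1 to compound 4 (0.36 log units; beyond the scatter) in this assay and so puts a size on what earlier could only be guessed from compounds that differ in several places. The step is modest but lies beyond the usual scatter, so the chain at this position does matter in this test, and here the shorter chain goes with lower toxicity. No measurement shown explains why the number moves, so this stands as an observation and not as an explanation.

From the compounds shown here alone, with only butyl and methyl to go on, it remains open how the number behaves in between or with other shapes at this position, and an ethyl chain or a cyclopropyl group there would help to show whether the change is gradual or abrupt. Going by these compounds, it also remains open whether butyl to methyl would give a step of similar size on a core carrying other groups, such as the two fluorophenyl groups of compound 2.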